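Notes on the amine substituent, compound 3 to compound 4

The source may hold more compounds than are shown below. What is called first, only, known or untested is meant among the compounds shown, and "the series" means these compounds.

Three compounds carry numbers in an assay for inhibition of Amine oxidase [flavin-containing] B (Rattus norvegicus), read by spectrophotometry; a higher number here means a weaker inhibitor, a lower number a stronger inhibitor:

compound 1 `Cc1c(C)c2ccc(OCCCCCN(C)Cc3ccccc3)cc2oc1=O`: 980 nM
compound 2 `CN(C)Cc1cccc(COc2ccc3ccc(=O)oc3c2)c1`: 3200 nM
compound 3 `CN(C)Cc1ccc(COc2ccc3ccc(=O)oc3c2)cc1`: 3700 nM

Compound 3 gives the highest of the three numbers in this assay. Its nearest neighbour is compound 2, whose number lies within the scatter of that of compound 3, so no order between the two can be read. Compound 1 shows a lower number than compound 3, and that gap lies beyond the scatter; the two differ in more than one place, so no single cause can be assigned.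

Compound 4 `COc1cccc(CN(C)Cc2ccc(COc3ccc4ccc(=O)oc4c3)cc2)c1` differs from compound 3 in one place: 3-methoxyphenyl in place of hydrogen on a saturated chain carbon bound to an amine nitrogen. Within the data shown here, no pair of measured compounds isolates this change, so the expectation rests on the wider picture only. Compound 1, which carries a benzyl group together with a methyl on its amine nitrogen, gives 980 nM, and this is the only hint that a larger substituent on the amine is tolerated or helpful in this assay. A modest step toward a lower number is therefore expected, a 2.5-fold lower number from compound 3 to compound 4 (0.39 log units; beyond the scatter), with real uncertainty since the hint comes from a compound altered elsewhere. Compound 4 is estimated at 1500 nM, with a range from 450 nM to 5000 nM.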

Compound 4, half-maximal inhibitory concentration: 2900 nM
Compound 4: the middle estimate sits 1.9-fold (0.29 log units) below what was measured; measured number inside the range.
By their numbers in this assay, from the lowest: compound 1; then compounds 4, 2 and 3 (each within the scatter of the next).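

Among these compounds, compound 3 and compound 4 form the first pair that differs in one place, and this assay gives a 1.3-fold lower number from compound 3 to compound 4 (0.11 log units; within the scatter) for 3-methoxyphenyl in place of hydrogen on a saturated chain carbon bound to an amine nitrogen. Read one bond further out, methyl gives way to 3-methoxybenzyl, so a group of 8 heavy atoms with one aromatic ring enters at this position with no change that can be read, and the pair lends no support to crediting the number of compound 1 to the benzyl group on its amine. Nothing at hand bears on why this substitution leaves the number within the scatter.

Still open, as far as these compounds go, is whether an unsubstituted phenyl, a 4-methoxyphenyl or a carboxylic acid on the same carbon would shift the number beyond the scatter. Also open, from the compounds shown here alone, is whether 3-methoxyphenyl at this position would give a similar result on compound 2, or with a longer chain in place of the methyl left on the amine nitrogen.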